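This account rests on a few compounds, and the source may have more. Where it says the series, first, only, none or still open, it means among the compounds named here.

Compound 3 `CCC(C)(C)Cc1c[nH]c(CCc2ccc(-n3ncnn3)cc2)n1` stands highest in an in vitro assay on CHO cells for displacement of a labelled ligand from Bombesin receptor subtype-3 (Homo sapiens), read by scintillation counting, with a stated time of 2 h (a lower number here means a stronger inhibitor, a higher number a weaker inhibitor), at 205 nM; compound 2 `CCC(C)(C)Cc1c[nH]c(CCc2ccc(-c3csnn3)cc2)n1` is nearest at 45 nM and compound 1 `CCC(C)(C)Cc1c[nH]c(CCc2ccc(-c3cccc(N)n3)cc2)n1` furthest at 7.3 nM. Both measured exchanges at this aromatic carbon point the same way, a 28-fold higher number from compound 1 to compound 3 (1.45 log units; beyond the scatter) and a 4.6-fold higher number from compound 2 to compound 3 (0.66 log units; beyond the scatter), so the 2H-tetrazol-2-yl ring gives the weakest binding of the three groups seen. Compound 4 `CCC(C)(C)Cc1c[nH]c(CCc2ccc(-n3ccnn3)cc2)n1` carries 1H-1,2,3-triazol-1-yl in place of 2H-tetrazol-2-yl on an aromatic carbon. Among the compounds with values here, no measured pair covers this exchange of one five-membered aromatic ring for another, so the direction rests only on the tetrazole being the poorest group so far. A modest step toward a lower number is expected, a 1.7-fold lower number from compound 3 to compound 4 (0.23 log units; within the scatter). Compound 4 is therefore estimated at 120 nM, with a range of 40 nM to 350 nM.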

Compound 4, half-maximal inhibitory concentration: 390 nM
For compound 4 the middle estimate is 3.3-fold (0.51 log units) below the measured one; measured number above the stated range.
By their numbers in this assay, from the lowest: compound 1; then compound 2; then compounds 3 and 4 (each within the scatter of the next).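

In this assay, 1H-1,2,3-triazol-1-yl in place of 2H-tetrazol-2-yl gives (a 1.9-fold higher number from compound 3 to compound 4 (0.28 log units; within the scatter)), so this exchange does not separate the two five-membered rings on this aromatic carbon. Compound 4 stays well apart from the other two groups, with (an 8.7-fold higher number from compound 2 to compound 4 (0.94 log units; beyond the scatter)) and (a 53-fold higher number from compound 1 to compound 4 (1.73 log units; beyond the scatter)). Nothing available explains these differences.

Open, as far as these compounds go, is whether the amine of 6-aminopyridin-2-yl contributes to binding, which an unsubstituted pyridine ring would test. Also open, from the compounds shown here alone, is how a carboxylic acid or a plain phenyl ring would behave on this aromatic carbon.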